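The source may report more compounds than this note shows. Statements on the series, on what has been measured and on what is new or still open speak of the compounds shown alone.

Measured so far in a functional assay on HCT-15 cells (Homo sapiens) for cytotoxicity, read by CCK-8 assay and cell counting, with a stated time of 2 days; on this read-out lower numbers stand for stronger inhibition and higher numbers for weaker inhibition: compound 1 `Oc1cccc(-c2cc(-c3ccccc3)nc(-c3cccc(Cl)c3)c2)c1` gives 2550 nM; compound 2 `Oc1ccc(-c2cc(-c3ccccc3)nc(-c3ccc(Cl)cc3)c2)cc1` gives 6920 nM.

Compound 2 stands at the higher of these two numbers, and compound 1 sits below it by more than the usual scatter, so compound 1 is the stronger inhibitor of the pair. Compound 3 `Oc1ccc(-c2cc(-c3ccccc3)nc(-c3cccc(Cl)c3)c2)cc1` differs from compound 2 in one place: 3-chlorophenyl in place of 4-chlorophenyl on an aromatic carbon. For the measured compounds named here, no pair of measured compounds differs by this change alone, so no measured step guides the expectation. A modest move toward a lower number is expected, a 1.7-fold lower number from compound 2 to compound 3 (0.24 log units; within the scatter), though it may stay within the scatter. For compound 3 the estimate in this assay is 4000 nM, in the range 1500 nM to 10000 nM.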

Compound 3, half-maximal inhibitory concentration: 6100 nM
Compound 3: the middle estimate sits 1.5-fold (0.18 log units) below what was measured; low and high end bracket the measured number.
By their numbers in this assay, from the lowest: compound 1; then compounds 3 and 2 (each within the scatter of the next).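

In this assay the swap of 4-chlorophenyl for 3-chlorophenyl next to the ring nitrogen makes no clear difference: a 1.1-fold lower number from compound 2 to compound 3 (0.05 log units; within the scatter) stays within the scatter. With 3-chlorophenyl held fixed, the place of the hydroxyl on the other ring matters more, as a 2.4-fold higher number from compound 1 to compound 3 (0.38 log units; beyond the scatter) lies beyond the scatter and favours 3-hydroxyphenyl. Nothing available explains this contrast. Still open, from the compounds shown here alone, is whether an amine or a carboxylic acid in place of the chlorine would move the number, and whether 3-hydroxyphenyl paired with 4-chlorophenyl would behave like compound 1.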